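This account rests on a few compounds, and the source may have more. Where it says the series, first, only, none or still open, it means among the compounds named here.

- Compound 1 `CC(C)(C)CC#Cc1cc2c(Nc3ccc(OCc4cccc(F)c4)c(Cl)c3)ncnc2s1`: > 50 uM
- Compound 2 `CN(C)CC#Cc1cc2c(Nc3ccc(OCc4cccc(F)c4)c(Cl)c3)ncnc2s1`: 41 uM

Among the measured compounds shown here, in an ADME assay on NIH3T3 cells (Mus musculus) for cytotoxicity (on this read-out lower numbers stand for higher toxicity in this test and higher numbers for lower toxicity in this test), compound 2 gives 41 uM, the only true number so far. Compound 1 gives > 50 uM, which is a limit of the assay and not a number.

Compound 3 `Fc1cccc(COc2ccc(Nc3ncnc4sc(C#CCN5CCNCC5)cc34)cc2Cl)c1` is the next to consider. Its change is piperazin-1-yl in place of dimethylamino on a saturated chain carbon bound to a triple-bonded carbon.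

For the measured compounds named here, only one measured step bears on this, as it changes the group at the same place: an at least 1.2-fold lower number from compound 1 to compound 2 (0.08 log units; that floor lies within the scatter), with dimethylamino in place of tert-butyl. That step gives no sign of a large effect, though it involves a different group and offers only a weak guide. The expected step is therefore small, with a slight lean towards higher toxicity and nothing beyond the scatter. The estimated step is a 1.3-fold lower number from compound 2 to compound 3 (0.11 log units; within the scatter). Compound 3 is expected at 32 uM, within an estimated range from 14 uM to 65 uM.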

Compound 3, half-maximal toxic concentration: 3.9 uM
Compound 3: middle estimate off by 8.2-fold (0.91 log units), on the high side; measured number outside the range, below it.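

In this assay, the group on a saturated chain carbon bound to a triple-bonded carbon can matter a great deal, which the earlier swap of tert-butyl for dimethylamino did not reveal: piperazin-1-yl in place of dimethylamino gives an 11-fold lower number from compound 2 to compound 3 (1.02 log units; beyond the scatter). Piperazin-1-yl in place of tert-butyl gives an at least 12-fold lower number from compound 1 to compound 3 (1.10 log units; beyond the scatter), so among these three groups piperazin-1-yl stands apart. This second step has only a floor, as the reading for compound 1 is a limit and not a number: the limit of > 50 uM in this assay, at which 1 of the 3 values shown sits.

The ring and the hydrogen-bond donor enter together in piperazin-1-yl, and the compounds shown do not separate them. A piperidin-1-yl group, with the ring but without the second nitrogen, and a 4-methylpiperazin-1-yl group, with a methyl on that nitrogen, would help tell the two apart.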